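Amine swap on the shared core: diethylamino to bromophenylamino

This account rests on a few compounds, and the source may have more. Where it says the series, first, only, none or still open, it means among the compounds named here.

Of the compounds shown here, three have been measured in a functional assay on NALM-6 cells (Homo sapiens) for cytotoxicity, read by MTT assay, with a stated time of 48 h; a higher number here means a weaker inhibitor, a lower number a stronger inhibitor. For the measured compounds named here, compound 1 `O=C(Nc1cc(C(F)(F)F)ccc1Nc1ccc(Br)cc1)c1cccnc1Cl` gives 35700 nM, and compound 2 `O=C(Nc1cc(C(F)(F)F)ccc1Nc1ccc(Br)cc1)c1ccncc1` gives 51900 nM; the one measured step, a 1.5-fold higher number from compound 1 to compound 2 (0.16 log units; within the scatter), concerns the amide aryl and stays within the scatter. Compound 3 `CCN(CC)c1ccc(C(F)(F)F)cc1NC(=O)c1cccnc1` gives 63200 nM, the highest of the three numbers, yet its distances to compound 2 and to compound 1 both stay within the scatter, so no order among the three can be read from these values.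

Compound 4 `O=C(Nc1cc(C(F)(F)F)ccc1Nc1ccc(Br)cc1)c1cccnc1` differs from compound 3 by (4-bromophenyl)amino in place of diethylamino on an aromatic carbon. Going by the values given here, no measured step bears on this position: the only step on record changes the carbonyl aryl, not the amine on the core. What the data offer instead is that compound 1 and compound 2 carry (4-bromophenyl)amino at this place and sit within the scatter of compound 3, which carries diethylamino. On that basis no step beyond the scatter is expected for this assay, in either direction.

Compound 4 is therefore expected to give 45000 nM, within a range of 15000 nM to 120000 nM. The estimated step of a 1.4-fold lower number from compound 3 to compound 4 (0.15 log units; within the scatter) is expected to stay within the scatter.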

Compound 4, half-maximal inhibitory concentration: 17000 nM
Estimate against measurement, compound 4: 2.6-fold (0.42 log units) above; measured number inside the range.
By their numbers in this assay, from the lowest: compound 4; then compounds 1, 2 and 3 (each within the scatter of the next).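

Working notes on the series: in this assay the position on the aromatic carbon para to the trifluoromethyl group now has a direct reading, with (4-bromophenyl)amino in place of diethylamino giving a modest step beyond the scatter (a 3.7-fold lower number from compound 3 to compound 4 (0.57 log units; beyond the scatter)), where the earlier compounds offered only a comparison across pairs differing in more than one place. The carbonyl aryl also proves less silent than the first step suggested, since with (4-bromophenyl)amino held fixed, pyridin-3-yl in place of pyridin-4-yl gives a modest step (a 3.1-fold lower number from compound 2 to compound 4 (0.48 log units; beyond the scatter)), as does hydrogen in place of chloro (a 2.1-fold lower number from compound 1 to compound 4 (0.32 log units; beyond the scatter)), which leaves compound 4 as the strongest of the four compounds. These three steps are all modest, and no measurement at hand accounts for any of them.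

On these data alone, the amine step rests on a single pair carrying pyridin-3-yl, so whether it holds with pyridin-4-yl or 2-chloropyridin-3-yl on the carbonyl carbon stays open. Also open, as far as these compounds go, is how a plain phenylamino, a 4-chlorophenylamino or a cyclic amine such as morpholine would compare at this aromatic carbon.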